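Replacing the imidazole side chain of compound 2

This account rests on a few compounds, and the source may have more. Where it says the series, first, only, none or still open, it means among the compounds named here.

Of the compounds shown here, three sharing one core have been measured in a functional assay on MDA-MB-231 cells (Homo sapiens) for cytotoxicity, read by MTT assay, with a stated time of 72 h; a lower number here means a stronger inhibitor, a higher number a weaker inhibitor. Compound 1 (`O=C1c2c[n+]([O-])c3ccccc3c2C(=O)c2c1c1ccccc1n2Cc1cn([C@H]2O[C@H](CO)[C@@H](O)[C@H]2O)nn1`) gives 1700 nM. Compound 2 (`O=C1c2c[n+]([O-])c3ccccc3c2C(=O)c2c1c1ccccc1n2CCCCn1ccnc1`) gives 210 nM. Compound 3 (`CC1(C)OCC(Cn2cc(Cn3c4c(c5ccccc53)C(=O)c3c[n+]([O-])c5ccccc5c3C4=O)nn2)O1`) gives 230 nM. This lies within the scatter of compound 2, so those two cannot be ranked, while both numbers lie well under that of compound 1.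

Compound 4 (`O=C1c2c[n+]([O-])c3ccccc3c2C(=O)c2c1c1ccccc1n2CCN1CCCC1`) keeps the core of compound 2 and alters its side chain: pyrrolidin-1-yl in place of 2-(1H-imidazol-1-yl)ethyl on a saturated chain carbon, two bonds along the chain from an aromatic nitrogen. Read one way, this is pyrrolidin-1-yl in place of 2-(1H-imidazol-1-yl)ethyl on a saturated chain carbon, two bonds along the chain from an aromatic nitrogen. Read further out, it is 4-(1H-imidazol-1-yl)butyl to 2-(pyrrolidin-1-yl)ethyl.

For the measured compounds named here, only one measured step bears on this, and indirectly: a 7.4-fold lower number from compound 1 to compound 3 (0.87 log units; beyond the scatter), with a different exchange of side groups. It shows that such a change can reach beyond the scatter. Against that, compound 2 at 210 nM and compound 3 at 230 nM carry unlike side chains yet stay level. Going by the values given here, no measured pair tests this exchange directly, so no shift beyond the scatter is expected, though with wide uncertainty. The expected change is a 1.1-fold lower number from compound 2 to compound 4 (0.02 log units; within the scatter). For compound 4 the estimated value is 200 nM, with an expected range of 70 nM to 600 nM.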

Compound 4, half-maximal inhibitory concentration: 630 nM
The estimate for compound 4 lay 3.2-fold (0.50 log units) below the measured number; the measured number lies above the stated range.
By their numbers in this assay, from the lowest: compounds 2 and 3 (each within the scatter of the next); then compound 4; then compound 1.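

In this assay, this exchange gives a 3.0-fold higher number from compound 2 to compound 4 (0.48 log units; beyond the scatter), so the side chain on the aromatic nitrogen of the shared core does not tolerate every change here. Compounds 2 and 3 had suggested that unlike side chains could stay level, but moving from 4-(1H-imidazol-1-yl)butyl to 2-(pyrrolidin-1-yl)ethyl, which replaces an aromatic five-membered ring with a non-aromatic one on a shorter chain, gives a weaker inhibitor beyond the scatter. Nothing measured here accounts for this shift.

The compounds shown leave open whether the ring or the chain length carries the step, since the two change together; a 4-(pyrrolidin-1-yl)butyl chain or a 2-(1H-imidazol-1-yl)ethyl chain on the same core would separate them. They also leave open how an open-chain amine such as dimethylamino, or a morpholine ring, would read at the end of the same ethyl chain.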